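The source may hold more compounds than are shown below. What is called first, only, known or untested is meant among the compounds shown, and "the series" means these compounds.

In a functional assay on HT-29 cells (Homo sapiens) for inhibition, read by luminescence and CellTiter-Glo, with a stated time of 10 h (on this read-out lower numbers stand for an effect already at smaller amounts and higher numbers for an effect only at larger amounts of compound), compound 1 `Cc1ccc2c(n1)OC[C@H](NC(=O)c1n[nH]c(Cc3ccccc3)n1)C(=O)N2C` gives 363 nM and compound 2 `Cc1cnc2c(c1)N(C)C(=O)[C@@H](NC(=O)c1n[nH]c(Cc3ccccc3)n1)CO2` gives 243 nM, two values within the usual scatter of each other. Compound 3 `CN1C(=S)[C@@H](NC(=O)c2n[nH]c(Cc3ccccc3)n2)COc2ncccc21` reads > 10000 nM in this assay, and this is a limit of the assay, not a number. That places it at the limit of > 10000 nM in this assay, at which 1 of the 3 values shown sits.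

Compound 4 `CN1C(=S)[C@H](NC(=O)c2n[nH]c(Cc3ccccc3)n2)COc2ncccc21` is the next to be tested. Its relation to compound 3 is simple: the two compounds have the same atoms and bonds and differ only in configuration as drawn: 1 of 1 stereo elements differ; a stereocentre at a saturated ring carbon is drawn S in compound 3 and R in compound 4. A stereocentre at a saturated ring carbon is drawn S in compound 3 and R in compound 4, so nothing is added or removed.

No measured pair among these compounds shows how much such a swap matters in this assay. The expectation therefore rests on one starting point, compound 3 at > 10000 nM, which is only a limit. The most likely outcome is no visible change, with compound 4 also reported as a limit. If a real number does appear, it can only lie on the lower side, which would mean an effect at smaller amounts. The expected step is a number no higher from compound 3 to compound 4 (the limit leaves the size open). For compound 4 the estimated value is 10000 nM, with an expected range from 2000 nM to 10000 nM.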

Compound 4, half-maximal effective concentration: > 10000 nM
Compound 4: a limit, no number; the forecaster's own chance of this, stated with the estimate: 75%; the middle value lies on the limit itself.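

For the compounds shown here, compound 3 and compound 4 differ only in the configuration as drawn, and compound 4 gives > 10000 nM as a limit of the assay and not a number, so no step between the two can be read. The compounds shown leave open whether this configuration matters at all in this assay when the rest of the structure is held the same.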